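Methyl on the amino nitrogen of compound 2

A few compounds are considered here, and "the series" means these few. Any claim that something is new, unique, unknown or untested is made for them only; others in the source may bear on it.

In a functional assay on KB cells (Homo sapiens) for inhibition (a higher number here means a weaker inhibitor, a lower number a stronger inhibitor), compound 1 `CCOC(=O)c1nc([C@@H]2O[C@H](CO)[C@@H](O)[C@H]2O)c(Cl)nc1Cl` gives 20000 nM. Compound 2 `CCOC(=O)c1nc([C@@H]2O[C@H](CO)[C@@H](O)[C@H]2O)c(N)nc1Cl`, with amino in place of chloro on an aromatic carbon, is reported only as a limit, > 100000 nM. Compound 2 therefore has no exact number, and its standing is given by the limit of > 100000 nM in this assay, at which 1 of the 2 values shown sits.

Compound 3 `CCOC(=O)c1nc([C@@H]2O[C@H](CO)[C@@H](O)[C@H]2O)c(NC)nc1Cl` makes one further change, amino to methylamino: methyl in place of hydrogen on a nitrogen on an aromatic ring. This places methyl in place of hydrogen on a nitrogen on an aromatic ring.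

Within the data shown here, the only measured step that bears on this is an at least 5.0-fold higher number from compound 1 to compound 2 (0.69 log units; beyond the scatter), which lies beyond the scatter. Among the measured compounds shown here, that step swapped chloro for amino, so no measured step covers methylation itself, and it offers only indirect guidance. On that single step, no shift beyond the scatter is expected in this assay, in either direction, and compound 3 is expected to remain weak, quite possibly reported as a limit too. The expected change is a number no higher from compound 2 to compound 3 (the limit leaves the size open). Compound 3 is estimated at 100000 nM, with an expected range of 30000 nM to 300000 nM.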

Compound 3, half-maximal inhibitory concentration: > 100000 nM
Compound 3: a limit, no number (the forecaster's own chance of this, stated with the estimate: 65%); the middle value lies on the limit itself.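

In this assay, compound 3 is reported only as a limit, > 100000 nM, so the two limits of compound 2 and compound 3 leave the effect of methyl on the amino nitrogen unreadable. What compound 3 adds is a second nitrogen group to compare with the chloro on this aromatic carbon: methylamino gives an at least 5.0-fold higher number from compound 1 to compound 3 (0.69 log units; beyond the scatter), a result that lies beyond the scatter and reads the same as the step already printed for amino, an at least 5.0-fold higher number from compound 1 to compound 2 (0.69 log units; beyond the scatter). With both amino and methylamino in this place, compound 1 remains the only compound of the three with an exact number, and the series now gathers at the ceiling of the read-out: the limit of > 100000 nM in this assay, at which 2 of the 3 values shown sit.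

As far as these compounds go, the size of any change from amino to methylamino stays open, as does whether compound 3 differs from compound 2 at all. Also open, from the compounds shown here alone, is whether dimethylamino, a longer chain such as ethylamino, or a methoxy group on this aromatic carbon would give an exact number in this assay.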